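The source may report more compounds than this note shows. Statements on the series, on what has been measured and on what is new or still open speak of the compounds shown alone.

Compound 1 `O=S(=O)(Nc1ccc(-c2nc3ccccc3o2)cc1)c1ccc(Cl)s1` carries a 5-chlorothiophen-2-yl group on its sulfonyl sulfur. In an assay on cells for inhibition of HSP60/HSP10 (Homo sapiens), with a stated time of 60 min (on this read-out lower numbers stand for stronger inhibition and higher numbers for weaker inhibition), compound 1 gives 31000 nM, the only number reported among these compounds. Compound 2 `O=S(=O)(Nc1ccc2oc(-c3ccccc3)nc2c1)c1cccc(Cl)c1` is reported in this assay only as a limit, > 100000 nM. For the measured compounds named here, compound 1 thus stands as the single measured value, the other result sitting at the limit of > 100000 nM in this assay, at which 1 of the 2 values shown sits. Compound 3 `COc1ccc(Cl)cc1S(=O)(=O)Nc1ccc(-c2nc3ccccc3o2)cc1` differs from compound 1 by 5-chloro-2-methoxyphenyl in place of 5-chlorothiophen-2-yl on a sulfonyl sulfur. Going by the values given here, with no measured step of this kind available, the expected change a 1.0-fold lower number from compound 1 to compound 3 (0.01 log units; within the scatter) is small, not beyond the usual scatter. Compound 3 is therefore estimated at 30000 nM, with a range from 10000 nM to 100000 nM.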

Compound 3, half-maximal inhibitory concentration: > 100000 nM
Compound 3: a limit, no number (the forecaster's own chance of this, stated with the estimate: 30%); at least 3.3-fold (0.52 log units) between middle value and limit.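

For the compounds shown here, on the sulfonyl sulfur, 5-chloro-2-methoxyphenyl in place of 5-chlorothiophen-2-yl gives an at least 3.2-fold higher number from compound 1 to compound 3 (0.50 log units; beyond the scatter) in this assay, the first readable step at this position, and it shows that the two chlorinated aromatic rings are not interchangeable here. The result for compound 3 is a limit and not a number. Only one compound in this small set now carries a number: the limit of > 100000 nM in this assay, at which 2 of the 3 values shown sit.

The compounds shown leave open whether the change of ring or the added methoxy group accounts for the step. They also leave open how a 5-bromothiophen-2-yl group or a carboxylic acid on the thiophene ring would read out at this position.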